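The source may report more compounds than this note shows. Statements on the series, on what has been measured and on what is new or still open speak of the compounds shown alone.

Two compounds sharing one spiro core set the scene here, and a third, still unmeasured, differs from one of them in a single place. Compound 1, with structure `N#CC1=C(N)Oc2c(c3nc4ccccc4nc3c3ccccc23)C12C(=O)N(Cc1cnnn1-c1ccc(N)cc1)c1ccccc12`, carries an amino group on the phenyl ring of its triazole arm. In a functional assay on MCF7 cells (Homo sapiens) for antiproliferative activity, read by MTT assay, with a stated time of 48 h (on this read-out higher numbers stand for weaker inhibition and lower numbers for stronger inhibition), compound 1 reaches only the limit of the assay, > 50000 nM, so no number is known for it. Compound 2, with structure `N#CC1=C(N)Oc2c(N)cc3nc4ccccc4nc3c2C12C(=O)N(Cc1cnnn1-c1ccc(F)cc1)c1ccccc12`, carries fluoro on that phenyl ring and an amino group on the core instead. In this assay compound 2 also reaches only the limit, > 50000 nM. Compound 2 therefore stands at the edge of what the assay can report, and the same holds for every value shown: the limit of > 50000 nM in this assay, at which 2 of the 2 values shown sit. Compound 3, with structure `N#CC1=C(N)Oc2c(N)cc3nc4ccccc4nc3c2C12C(=O)N(Cc1cnnn1-c1ccc([N+](=O)[O-])cc1)c1ccccc12`, differs from compound 2 in one place: nitro in place of fluoro on an aromatic carbon. Among the compounds with values here, no step between two measured compounds exists to gauge how large such a swap can be. The step from compound 2 to compound 3 is expected to be a number no higher from compound 2 to compound 3 (the limit leaves the size open), nothing beyond the scatter. Compound 3 is expected to give 50000 nM in this assay, within a range from 20000 nM to 100000 nM, and most likely only a limit again.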

Compound 3, half-maximal inhibitory concentration: > 50000 nM
Compound 3: no number, only a limit; the forecaster's own chance of this, stated with the estimate: 80%; the middle value lies on the limit itself.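

Compound 2 and compound 3 each give only a limit in this assay, so no step can be read for the swap from fluoro to nitro. The compounds shown leave open how strongly any of them inhibits these cells and how much any single change matters, because no actual number is available: the limit of > 50000 nM in this assay, at which 3 of the 3 values shown sit.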